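The compounds below may be only part of what the source reports. "The series", "measured", "known", "first", "only" and "open" are said of these compounds alone.

Of the compounds shown here, three on a shared core have so far been measured in an ADME assay on MT4 cells (Homo sapiens) for cytotoxicity, read by MTT assay, with a stated time of 5 days (a higher number here means that more compound is tolerated, a lower number that less compound is tolerated), by the same read-out. Compound 1 (`Cc1cc(C)cc(S(=O)(=O)c2c(C(=O)NC3CNC3)[nH]c3ccc(Cl)cc23)c1`) stands at 37300 nM and compound 2 (`Cc1cc(C)cc(S(=O)(=O)c2c(C(=O)N[C@@H]3CCN(S(C)(=O)=O)C3)[nH]c3ccc(Cl)cc23)c1`) at 24000 nM on this measure. Compound 3 (`Cc1cc(C)cc(S(=O)(=O)c2c(C(=O)N[C@H]3CCN(Cc4n[nH]c(=O)n4C)C3)[nH]c3ccc(Cl)cc23)c1`) gives 21500 nM and so sits within the scatter of both. Compound 4 (`Cc1cc(C)cc(S(=O)(=O)c2c(C(=O)N[C@H]3CCN(CC(N)=O)C3)[nH]c3ccc(Cl)cc23)c1`) has not yet been measured. It differs from compound 3 at one place (a group of 3 heavy atoms (1 carbon, 1 nitrogen, 1 oxygen; no ring) in place of a group of 7 heavy atoms (3 carbon, 3 nitrogen, 1 oxygen; one five-membered aromatic ring with 3 hetero atoms), on a saturated chain carbon bound to an amine nitrogen in a ring) where carbamoyl enters. Within the data shown here, the only measured single-place step (a 1.6-fold lower number from compound 1 to compound 2 (0.19 log units; within the scatter)) lies within the scatter, but it exchanges a different group on an amide-type nitrogen, so it bears on this change only indirectly. Among the measured compounds shown here, no measured step covers the carbamoyl exchange itself. Starting from compound 3 at 21500 nM and given the small step (a 1.6-fold lower number from compound 1 to compound 2 (0.19 log units; within the scatter)) no step beyond the scatter is expected in this assay here. The expected step (a 1.2-fold higher number from compound 3 to compound 4 (0.07 log units; within the scatter)) stays within that scatter. Compound 4 is estimated at 25000 nM with an expected range of 12000 nM to 50000 nM on this measure.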

Compound 4, half-maximal cytotoxic concentration: 28100 nM
Compound 4: the middle estimate sits 1.1-fold (0.05 log units) below what was measured; the range from low to high includes it.
By their numbers in this assay, from the lowest: compounds 3, 2, 4 and 1 (each within the scatter of the next).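

In this assay, carbamoyl in place of the group carrying the five-membered aromatic ring with 3 hetero atoms, on a saturated chain carbon bound to an amine nitrogen in a ring, gives a 1.3-fold higher number from compound 3 to compound 4 (0.12 log units; within the scatter), so removing that ring at this place does not shift the number beyond the scatter. On an amide-type nitrogen, 1-(carbamoylmethyl)pyrrolidin-3-yl gives a 1.2-fold higher number from compound 2 to compound 4 (0.07 log units; within the scatter) and a 1.3-fold lower number from compound 1 to compound 4 (0.12 log units; within the scatter), so none of these exchanges moves the number beyond the scatter either. No evidence at hand bears on this result.

The compounds shown leave open whether a primary amine, a carboxylic acid or a longer chain in place of carbamoyl at this place would also stay within the scatter in this assay. They also leave open how the carbamoyl exchange reads on any other measure.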